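The source may report more compounds than this note shows. Statements on the series, on what has been measured and on what is new or still open speak of the compounds shown alone.

Three compounds have been measured in a physicochemical assay for solubility, with a stated time of 18 h, at pH 7.4; on this read-out higher numbers stand for higher solubility and lower numbers for lower solubility:

Compound 1, `COc1cccc(Oc2ccc3c(NCCCNCc4ccco4)ccnc3c2)c1`, gives 14500 nM.
Compound 2, `COc1cccc(Oc2ccc3c(NCCCNCc4cccc(OC)c4O)ccnc3c2)c1`, gives 14500 nM.
Compound 3, `Fc1ccc(Cc2ccc3c(NCCCNCc4ccco4)ccnc3c2)cc1`, gives 4200 nM.

Compound 1 and compound 2 share a core and differ only in one group: 2-hydroxy-3-methoxyphenyl in place of furan-2-yl on a saturated chain carbon bound to an amine nitrogen. This change made a step of no change at the digits printed from compound 1 to compound 2 (within the scatter) in this assay. Compound 3 carries a different group on the core: 4-fluorobenzyl in place of 3-methoxyphenoxy on an aromatic carbon. That change made a step of a 3.5-fold lower number from compound 1 to compound 3 (0.54 log units; beyond the scatter), and compound 3 stands lowest among the three measured numbers.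

Compound 4, `COc1cccc(CNCCCNc2ccnc3cc(Cc4ccc(F)cc4)ccc23)c1O`, is not yet measured. It differs from compound 3 in one place: 2-hydroxy-3-methoxyphenyl in place of furan-2-yl on a saturated chain carbon bound to an amine nitrogen. Going by the values given here, this is the same change as the one from compound 1 to compound 2, at a place described in the same words, but now on the core of compound 3. Because the earlier step was no change at the digits printed from compound 1 to compound 2 (within the scatter), the step from compound 3 to compound 4 in this assay is expected to be no change at the digits printed from compound 3 to compound 4 (within the scatter). On that basis compound 4 is estimated at 4200 nM, with a likely range from 1800 nM to 9500 nM.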

Compound 4, solubility: 4200 nM
Compound 4: middle estimate and measured number agree at the digits printed, and the stated range covers the measured number.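

In this assay, placing 2-hydroxy-3-methoxyphenyl where furan-2-yl stood gave no change at the digits printed from compound 3 to compound 4 (within the scatter) and, on the other core, no change at the digits printed from compound 1 to compound 2 (within the scatter) so across these two cores the change carried over with the same outcome. Read the other way, 4-fluorobenzyl in place of 3-methoxyphenoxy gave a 3.5-fold lower number from compound 2 to compound 4 (0.54 log units; beyond the scatter) and likewise a 3.5-fold lower number from compound 1 to compound 3 (0.54 log units; beyond the scatter) so in these four compounds each change gave the same step whichever form of the other place was present. This does not show that the change would carry over to any further core, and nothing on hand explains why either step came out as it did.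

The compounds shown leave open whether the same agreement would hold with a carboxylic acid or a morpholine in place of furan-2-yl. They also leave open what a longer chain would do on either core.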